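Swapping the amine on a dithiocarbamate linked to an aminobenzamide

The compounds below may be only part of what the source reports. "The series", "measured", "known", "first", "only" and "open" are said of these compounds alone.

Measured so far:
- compound 1, `Nc1ccccc1NC(=O)c1ccc(CSC(=S)N2CCN(Cc3ccccn3)CC2)cc1`, 23.4%
- compound 2, `CC1CCN(C(=S)SCc2ccc(C(=O)Nc3ccccc3N)cc2)CC1`, 28.1%

Both compounds were tested in a functional assay on MGC-803 cells (Homo sapiens) for antiproliferative activity, read by CCK-8 assay, with a stated time of 72 h, tested at 2 uM; a higher number here means a stronger effect of the compound at the concentration tested, a lower number a weaker effect. Compound 1 gives 23.4%, and compound 2 gives 28.1%. Compound 2 holds the higher of the two numbers, but the gap to compound 1 falls within the scatter of this assay, so the two read as equal in effect.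

Compound 3, `CN(C(=S)SCc1ccc(C(=O)Nc2ccccc2N)cc1)c1cccnc1`, has not yet been measured. It differs from compound 2 in a single place: methyl(pyridin-3-yl)amino in place of 4-methylpiperidin-1-yl on a thiocarbonyl carbon. Among the measured compounds shown here, no measured pair here shows what exchanging one amine on a thiocarbonyl carbon for another does, so there is no step in this assay to lean on. The two measured compounds, with different amines at that same place, sit within the scatter of each other, which hints that this position tolerates variation.

The step from compound 2 to compound 3 is therefore expected to be small, a number 2.1 percentage points lower from compound 2 to compound 3 (within the scatter), with no clear direction beyond the scatter. For compound 3 the expected value is 26%, with a range from 10% to 45%.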

Compound 3, a percentage reported as inhibition, at one concentration (the size of the read-out at that concentration, not a potency): 46.1%
Compound 3: the middle estimate sits 20.1 percentage points below what was measured; measured number above the stated range.
By their numbers in this assay, from the lowest: compounds 1 and 2 (each within the scatter of the next); then compound 3.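

Exchanging 4-methylpiperidin-1-yl for methyl(pyridin-3-yl)amino on a thiocarbonyl carbon gives a number 18 percentage points higher from compound 2 to compound 3 (beyond the scatter) in this assay. This shows that the amine at this place can change the read-out, something compound 1 and compound 2, whose values lie within the scatter of each other, gave no sign of. Nothing available here accounts for the rise, so the change can be described only by what it swaps: a non-aromatic ring for an aromatic one carrying a hydrogen-bond acceptor.

The compounds shown leave open which part of the entering group goes with the step: the aromatic ring, its ring nitrogen or the methyl on the amine. A methyl(phenyl)amino group at the same place would separate the ring from its nitrogen.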